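Chloromethyl in Place of Carboxy on a Ring Carbon

A few compounds are considered here, and "the series" means these few. Any claim that something is new, unique, unknown or untested is made for them only; others in the source may bear on it.

Going by the values given here, in a functional assay on MCF7 cells (Homo sapiens) for antiproliferative activity, read by MTT assay, with a stated time of 48 h (on this read-out higher numbers stand for weaker inhibition and lower numbers for stronger inhibition), compound 2 (`CC(C)=CCC[C@]1(C)/C=C/[C@@H](OC(=O)C=C(C)C)[C@](C)(O)/C=C/C(=O)/C(C(=O)O)=C\C1`) gives 16100 nM and holds the higher of the two numbers so far, while compound 1 (`COC/C1=C/C[C@](C)(CCC=C(C)C)/C=C/[C@@H](OC(=O)C=C(C)C)[C@](C)(O)/C=C/C1=O`) gives 4130 nM on the same read-out. Compound 3 (`CC(C)=CCC[C@]1(C)/C=C/[C@@H](OC(=O)C=C(C)C)[C@](C)(O)/C=C/C(=O)/C(CCl)=C\C1`) carries chloromethyl in place of carboxy on a double-bonded ring carbon and otherwise matches compound 2.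

Among the compounds with values here, only one measured step bears on this ring carbon. That step, a 3.9-fold higher number from compound 1 to compound 2 (0.59 log units; beyond the scatter) with carboxy in place of methoxymethyl, is modest but beyond the scatter. Within the data shown here, no chloromethyl compound has been measured, so any comparison remains tentative. Chloromethyl is judged closer to the methoxymethyl of compound 1 (4130 nM) than to carboxy, so a modest move toward a lower number is expected in this assay rather than no change. The estimate is for a 3.2-fold lower number from compound 2 to compound 3 (0.51 log units; beyond the scatter) in this read-out. For compound 3 the estimated value is 5000 nM with an expected range from 1500 nM to 15000 nM that stays wide since it rests on a single step.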

Compound 3, half-maximal inhibitory concentration: 610 nM
The estimate for compound 3 lay 8.2-fold (0.91 log units) above the measured number, and the stated range ends above it.
By their numbers in this assay, from the lowest: compound 3; then compound 1; then compound 2.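

In this assay, going by these compounds alone, this double-bonded ring carbon turns out to be far more sensitive to its substituent than the single earlier step indicated: chloromethyl in place of carboxy gives a 26-fold lower number from compound 2 to compound 3 (1.42 log units; beyond the scatter), a large step where the earlier one, a 3.9-fold higher number from compound 1 to compound 2 (0.59 log units; beyond the scatter), was modest. The comparison with the methoxymethyl compound adds a second point, since chloro in place of methoxy on the saturated chain carbon bound to that ring carbon gives a 6.8-fold lower number from compound 1 to compound 3 (0.83 log units; beyond the scatter), so the atom on this chain carbon matters in its own right and the loss of carboxy is not the whole of the gain, with compound 3 now lowest of the three by steps beyond the scatter. Nothing available here accounts for either step.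

The three compounds leave open whether the lower number is specific to chloromethyl or would also appear with bromomethyl, hydroxymethyl, aminomethyl or a plain methyl at this ring carbon. They also leave open how a longer chain carrying chlorine at its end would read, and whether the hydroxy group or the ((2-methylprop-1-en-1-yl)carbonyl)oxy group elsewhere on the shared core contributes to the effect.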